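Trifluoromethoxy for trifluoromethyl: an expected oral bioavailability

This account rests on a few compounds, and the source may have more. Where it says the series, first, only, none or still open, it means among the compounds named here.

Compound 1 `O[C@]1(Cc2cc(-c3cn[nH]c3)on2)CC[C@H](Cc2ccc(Cl)cc2)CC1`: 72.8%
Compound 2 `O[C@]1(Cc2cc(-c3cn[nH]c3)on2)CC[C@H](Cc2ccc(F)cc2)CC1`: 78%
Compound 3 `O[C@]1(Cc2cc(-c3cn[nH]c3)on2)CC[C@H](Cc2ccc(C(F)(F)F)cc2)CC1`: 67.5%

These three compounds share one core and differ only in a single group on the aromatic ring. In an ADME assay on the whole organism (strain Sprague-Dawley) for pharmacokinetics, with Rattus norvegicus as the target, using cassette dosing, at a dose of 1 mg/kg by the oral route (on this read-out lower numbers stand for lower oral bioavailability and higher numbers for higher oral bioavailability), compound 3 gives 67.5%. Two steps place it among the others: a number 5.3 percentage points lower from compound 1 to compound 3 (within the scatter), which lies within the scatter, and a number 10.5 percentage points lower from compound 2 to compound 3 (beyond the scatter), which lies beyond the scatter but remains modest.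

The next structure is compound 4 `O[C@]1(Cc2cc(-c3cn[nH]c3)on2)CC[C@H](Cc2ccc(OC(F)(F)F)cc2)CC1`, and the change is a single exchange of groups: trifluoromethoxy in place of trifluoromethyl on an aromatic carbon. Trifluoromethoxy stands in place of trifluoromethyl on an aromatic carbon. Going by the values given here, no measured step covers this exact exchange. The closest evidence is the three exchanges on that same aromatic carbon: the two steps above and a number 5.2 percentage points higher from compound 1 to compound 2 (within the scatter), which is also within the scatter. Only one of the three goes beyond the scatter, and then only modestly. No step beyond the scatter is therefore expected in this assay, and no direction can be argued with confidence. The expected step is a number 1.5 percentage points higher from compound 3 to compound 4 (within the scatter). Compound 4 is estimated at 69%, with an expected range from 55% to 81%.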

Compound 4, oral bioavailability: 121%
Compound 4: middle estimate off by 52 percentage points, on the low side; the measured number lies above the stated range.
By their numbers in this assay, from the lowest: compounds 3, 1 and 2 (each within the scatter of the next, the first and the last beyond it); then compound 4.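

In this assay, going by these compounds alone, the aromatic carbon para to a large group turns out to tolerate far more change than the earlier compounds suggested: the exchange of trifluoromethyl for trifluoromethoxy gives a number 53.5 percentage points higher from compound 3 to compound 4 (beyond the scatter), whereas the exchanges among chloro, fluoro and trifluoromethyl stayed within the scatter or only modestly beyond it. The jump does not depend on trifluoromethyl as the point of comparison, since the same group gives a number 43 percentage points higher from compound 2 to compound 4 (beyond the scatter) and a number 48.2 percentage points higher from compound 1 to compound 4 (beyond the scatter), which sets compound 4 apart from all three other compounds on a change of a single group. Nothing measured here bears on what lies behind this large rise.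

From the compounds shown here alone, what remains open is whether the rise belongs to an oxygen linking the group to the ring or to trifluoromethoxy as a whole, and a methoxy or difluoromethoxy group on the same aromatic carbon would separate the two. With only compound 4 carrying such a linked group, the compounds shown also leave open whether this number reflects a trend or stands alone.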